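A few compounds are considered here, and "the series" means these few. Any claim that something is new, unique, unknown or untested is made for them only; others in the source may bear on it.

Measured in a functional assay on DU-145 cells (Homo sapiens) for inhibition, read by trypan blue exclusion, with a stated time of 96 h; on this read-out lower numbers stand for stronger inhibition of growth and higher numbers for weaker inhibition of growth:
- compound 1 `Cc1ccc(S/C(=C/c2ccc(N(C)C)cc2)C(=O)c2ccc(Cl)cc2)cc1`: > 100000 nM, a limit of the assay and not a number
- compound 2 `Cc1ccc(S/C(=C/c2cc(Cl)cc(Cl)c2Cl)C(=O)c2ccc(Cl)cc2)cc1`: 50000 nM
- compound 3 `Cc1ccc(S/C(=C/c2ccc[nH]2)C(=O)c2ccc(Cl)cc2)cc1`: 10000 nM

Compound 3 holds the lowest number in the series, at 10000 nM, and compound 2 is its nearest measured neighbour. Compound 4 `Cc1ccc(S/C(=C/c2c[nH]c3ccccc23)C(=O)c2ccc(Cl)cc2)cc1` carries 1H-indol-3-yl in place of 1H-pyrrol-2-yl on a double-bonded chain carbon bound to a double-bonded chain carbon. All measured steps fall at this same place. The two that bear most directly lead to the pyrrole of compound 3 from a phenyl-bearing compound: a 5.0-fold lower number from compound 2 to compound 3 (0.70 log units; beyond the scatter), and an at least 10-fold lower number from compound 1 to compound 3 (1.00 log units; beyond the scatter). The remaining step, an at least 2.0-fold lower number from compound 1 to compound 2 (0.30 log units; that floor lies within the scatter), adds little. The incoming indole keeps a five-membered aromatic ring but adds a six-membered aromatic ring of carbon only, a ring type present in the substituted phenyl groups of both higher-number compounds. A small move toward a higher number in this assay is therefore expected, though probably not one beyond the scatter. The estimated step is a 1.5-fold higher number from compound 3 to compound 4 (0.18 log units; within the scatter). The estimate for compound 4 is 15000 nM. The expected range runs from 3000 nM to 60000 nM.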

Compound 4, concentration for 50% growth inhibition: 10000 nM
Estimate against measurement, compound 4: 1.5-fold (0.18 log units) above, within the range that was stated.
By their numbers in this assay, from the lowest: compounds 3 and 4 (each within the scatter of the next); then compound 2. At a limit, above all of these: compound 1.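

Notes on this position: in this assay, the six-membered aromatic ring of carbon only that 1H-indol-3-yl adds to the five-membered aromatic ring leaves the read-out unmoved on the double-bonded chain carbon: no change at the digits printed from compound 3 to compound 4 (within the scatter). Such a ring therefore does not by itself go with the higher numbers of the phenyl-bearing compounds, and the indole stands apart from the 2,3,5-trichlorophenyl compound: a 5.0-fold lower number from compound 2 to compound 4 (0.70 log units; beyond the scatter). The gap to the 4-(dimethylamino)phenyl compound is only a floor, an at least 10-fold lower number from compound 1 to compound 4 (1.00 log units; beyond the scatter), with compound 1 standing at a limit: the limit of > 100000 nM in this assay, at which 1 of the 4 values shown sits.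

Open, from the compounds shown here alone, is whether the attachment point matters, since the pyrrole is joined through its 2-yl carbon and the indole through its 3-yl carbon; 1H-indol-2-yl would separate the two. Also open, going by these compounds, is the role of the ring nitrogen hydrogen, which a 1-methyl-1H-indol-3-yl group would test.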